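The source may hold more compounds than are shown below. What is called first, only, known or untested is meant among the compounds shown, and "the series" means these compounds.

Values in a functional assay on HCT-116 cells (Homo sapiens) for inhibition, read by MTT assay, with a stated time of 72 h; on this read-out higher numbers stand for weaker inhibition and lower numbers for stronger inhibition:
- compound 1 `O=C(NO)c1ccc(CNCc2nc(-c3ccc(C(F)(F)F)cc3)no2)cc1`: 43100 nM
- compound 2 `O=C(NO)c1ccc(CNCc2nc(-c3ccc(Cl)cc3)no2)cc1`: 30200 nM
- compound 3 `O=C(NO)c1ccc(CNCc2nc(-c3ccc([N+](=O)[O-])cc3)no2)cc1`: not yet measured

Within the data shown here, compound 2 stands level with compound 1, its only measured neighbour, and the two cannot be ranked. The gap between them is a 1.4-fold lower number from compound 1 to compound 2 (0.15 log units; within the scatter).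

The next change is nitro in place of chloro on an aromatic carbon. In words, this is nitro in place of chloro on an aromatic carbon, para to a large group, or 4-chlorophenyl to 4-nitrophenyl.

Among the measured compounds shown here, one measured step bears on this change, an exchange of one group for another at the same place. For the measured compounds named here, no measurement yet shows what nitro does, so the basis is thin. Going by a 1.4-fold lower number from compound 1 to compound 2 (0.15 log units; within the scatter), no step beyond the scatter is expected in this assay, in either direction. The expected step is a 1.1-fold higher number from compound 2 to compound 3 (0.03 log units; within the scatter). Compound 3 is estimated at 32000 nM, with an expected range from 13000 nM to 75000 nM.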

Compound 3, half-maximal inhibitory concentration: 21900 nM
For compound 3 the middle estimate is 1.5-fold (0.16 log units) above the measured one; the range from low to high includes it.
By their numbers in this assay, from the lowest: compounds 3, 2 and 1 (each within the scatter of the next).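

Nitro, with 3 heavy atoms and 2 hydrogen-bond acceptors, is a larger exchange at this aromatic carbon, para to a large group, than the earlier one, yet in this assay the 4-chlorophenyl to 4-nitrophenyl change gives only a 1.4-fold lower number from compound 2 to compound 3 (0.14 log units; within the scatter). Among these compounds, the exchange of nitro for trifluoromethyl, read across the same place, gives a 2.0-fold lower number from compound 1 to compound 3 (0.29 log units; within the scatter), so chloro, trifluoromethyl and nitro all stand level here and cannot be ranked, which the single earlier step could not show for a group carrying hydrogen-bond acceptors. Nothing at hand gives any explanation for these numbers.

The compounds shown leave open whether an amine, a carboxylic acid or a methoxy group at this place would give a step beyond the scatter in this assay. They also leave open whether a change elsewhere in the shared core, such as a longer chain, would shift the number by more than these three exchanges at the aromatic carbon do.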